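Working notes: from compound 2 to compound 3

The compounds below may be only part of what the source reports. "The series", "measured", "known", "first", "only" and "open" are said of these compounds alone.

In a functional assay on K562 cells (Homo sapiens) for cytotoxicity, read by trypan blue exclusion, with a stated time of 96 h (a higher number here means a weaker inhibitor, a lower number a stronger inhibitor), compound 1 (`COC(=O)C(Nc1cc(NS(=O)(=O)/C=C/c2c(OC)cc(OC)cc2OC)ccc1OC)c1ccccc1`) gives 2500 nM, and compound 2 (`COC(=O)C(Nc1cc(NS(=O)(=O)/C=C/c2c(OC)cc(OC)cc2OC)ccc1OC)c1ccc(F)cc1`) gives 2500 nM, so the two stand level. Compound 2 therefore has no measured neighbour that separates from it.

The next structure is compound 3 (`COc1cc(OC)c(/C=C/S(=O)(=O)Nc2ccc(OC)c(NCC(=O)O)c2)c(OC)c1`), with carboxymethyl in place of (4-fluorophenyl)(methoxycarbonyl)methyl on a nitrogen on an aromatic ring.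

Among the measured compounds shown here, only one measured step bears on this change, and only weakly. Fluoro in place of hydrogen on an aromatic carbon gave no change at the digits printed from compound 1 to compound 2 (within the scatter). That step touches a single carbon of the group now leaving. For the measured compounds named here, no measured compound lacks that group, so the data give no direct measure of removing it, and the size of the coming step cannot be read from them.

The expected step, a 3.1-fold lower number from compound 2 to compound 3 (0.49 log units; beyond the scatter), points towards a stronger inhibitor in this assay, but this is a loose estimate and a step in the other direction is not excluded. For compound 3 the estimated value is 800 nM, with an expected range of 80 nM to 5000 nM.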

Compound 3, half-maximal inhibitory concentration: 20 nM
Beside the measured number, compound 3's estimate is 40-fold (1.60 log units) above it, outside the stated range (below it).
By their numbers in this assay, from the lowest: compound 3; then compounds 1 and 2 (each within the scatter of the next).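

In this assay, the group on the nitrogen on the aromatic ring proves far more sensitive to change than the earlier fluoro step suggested: carboxymethyl in place of (4-fluorophenyl)(methoxycarbonyl)methyl gives a 130-fold lower number from compound 2 to compound 3 (2.10 log units; beyond the scatter) and, against the unfluorinated group, gives a 130-fold lower number from compound 1 to compound 3 (2.10 log units; beyond the scatter) with the same size. Compounds 1 and 2 only varied one carbon of the outer aromatic ring, whereas this change replaces the whole group, so the shared core tolerates a much smaller substituent at this nitrogen and gains strongly with it. The change removes the six-membered aromatic ring and the methyl of the ester together, and adds a hydrogen-bond donor, and nothing at hand bears on the cause of the step.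

Which of these differences carries the step stays open, since a methoxycarbonylmethyl group would separate the free carboxylic acid from the loss of the ring, and a phenyl-bearing carboxylic acid would test the same question from the other side. How far the gain extends to a longer chain such as carboxyethyl, or to a primary amide in place of the carboxylic acid, is also unresolved.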